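The source may report more compounds than this note shows. Statements on the series, on what has been measured and on what is new or still open speak of the compounds shown alone.

Working notes on the series.

Two compounds have numbers in an assay on nucleic acid for binding affinity to Salmon testes DNA (Salmonidae), tested at 10 uM; on this read-out higher numbers stand for stronger stabilisation of the target against heat and lower numbers for weaker stabilisation of the target. Compound 1, `CC(C)CCc1sc(NC(=O)c2cc(NC(=O)c3cc(NC(=N)c4cccc(F)c4)cn3C)cn2C)nc1C(=O)NCCCN(C)C`, gives 4 degrees C in this assay. Compound 2, `CC(C)CCn1cc(NC(=O)c2cc(NC(=O)c3cc(NC(=N)c4ccccc4)cn3C)cn2C)cc1C(=O)NCCCN(C)C`, gives 8 degrees C in this assay, a value that sits beyond the scatter above that of compound 1. Compound 1 therefore stands lowest of the two measured compounds. Going by the values given here, no pair of measured compounds differs in a single place, so no step between them can be isolated to one change.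

Compound 3, `CC(C)CCc1sc(NC(=O)c2cc(NC(=O)c3cc(NC(=N)c4cnc5ccccc5c4)cn3C)cn2C)nc1C(=O)NCCCN(C)C`, is not yet measured. It differs from compound 1 by quinolin-3-yl in place of 3-fluorophenyl on a carbon with a double bond to nitrogen. The change is confined to the group on the carbon with a double bond to nitrogen; the rest of compound 1 is kept.

Among the compounds with values here, nothing among the measured compounds shows what quinolin-3-yl in place of 3-fluorophenyl does in this assay. A modest rise is expected for compound 3, with an estimated step of a number 1.0 degrees C higher from compound 1 to compound 3 (within the scatter), which may not clear the scatter. For compound 3 an estimated value of 5 degrees C in this assay is expected, in the range from 2 degrees C to 9 degrees C.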

Compound 3, shift of the target's melting temperature: 2 degrees C
Compound 3: the middle estimate sits 3.0 degrees C above what was measured, within the range that was stated.
By their numbers in this assay, from the lowest: compound 3; then compound 1; then compound 2.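

In this assay, going by these compounds alone, quinolin-3-yl in place of 3-fluorophenyl on a carbon with a double bond to nitrogen comes with a number 2.0 degrees C lower from compound 1 to compound 3 (beyond the scatter), and this is the only change so far that can be read at a single place. The read-out therefore responds to the group at this position, and on this one pair the entering group, with its additional heavy atoms, second six-membered aromatic ring and hydrogen-bond acceptor, brings no gain over 3-fluorophenyl. Nothing available bears on why the number falls or on which of these differences matters.

From the compounds shown here alone, compound 2 differs from compound 1 and compound 3 in more than one place, so its higher value cannot be read as the effect of any single group, and what separates it from them stays open. Also open, going by these compounds, is how a pyridin-3-yl or a 3-aminophenyl on the same carbon of the core of compound 1 would stand, since such groups would help separate the contribution of the second ring from that of the ring nitrogen in quinolin-3-yl.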